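Oxime series: hydroxy added on the chain of compound 2

The compounds below may be only part of what the source reports. "The series", "measured", "known", "first", "only" and "open" are said of these compounds alone.

Measured so far:
compound 1, `O/N=C(\CCN1CCN(c2ccccn2)CC1)c1ccccc1`, 4.4 nM in a functional assay on HEK293 cells with D(4) dopamine receptor (Homo sapiens) as the target, read by FLIPR; a lower number here means that less compound is needed, a higher number that more compound is needed for the effect
compound 2, `Cc1cccc(/C(CCN2CCN(c3ccccn3)CC2)=N/O)c1`, 2.3 nM in this assay

Among the compounds with values here, compound 2 stands at the lowest of the two numbers in this assay; its nearest neighbour is compound 1, and the only step recorded so far, a 1.9-fold lower number from compound 1 to compound 2 (0.28 log units; within the scatter), lies within the scatter, so the two compounds cannot be told apart on these values.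

The next compound, compound 3, is `Cc1cccc(/C(=N/O)C(O)CN2CCN(c3ccccn3)CC2)c1`. It differs from compound 2 by hydroxy in place of hydrogen on a saturated chain carbon bound to a carbon with a double bond to nitrogen and a saturated chain carbon. Within the data shown here, no measured step bears on this change: the one step available concerns a methyl on an aromatic carbon and says nothing about a hydroxy on the chain that joins the oxime carbon to the basic ring. The expectation for this assay therefore rests on compound 2 alone, with no direction supported beyond the scatter.

Compound 3 is estimated at 5 nM in this assay, with a range of 1.5 nM to 25 nM. This estimate means a step of a 2.2-fold higher number from compound 2 to compound 3 (0.34 log units; beyond the scatter), which is expected to stay close to the scatter, with the wide range reflecting the absence of any comparable step.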

Compound 3, half-maximal effective concentration: 4.9 nM
Compound 3: the middle estimate sits 1.0-fold (0.01 log units) above what was measured; measured number inside the range.
By their numbers in this assay, from the lowest: compounds 2, 1 and 3 (each within the scatter of the next, the first and the last beyond it).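

Working notes on the chain position: in this assay, hydroxy in place of hydrogen on a saturated chain carbon bound to a carbon with a double bond to nitrogen and a saturated chain carbon gives a 2.1-fold higher number from compound 2 to compound 3 (0.33 log units; beyond the scatter). Within the data shown here, this is the first reading at this position and the first single step to pass the scatter, though only modestly, whereas the earlier methyl change on the aromatic carbon stayed within it. The position therefore accepts the added hydroxy with a small rise in the number, and compound 3 remains at 4.9 nM; nothing available explains the shift.

The compounds shown leave open whether this step is specific to hydroxy or would also appear with a methoxy group, a fluorine atom, an amine or a carbonyl at the same carbon. They also leave open whether hydroxy at this position would give a similar step on compound 1, which lacks the aromatic methyl, and so whether the effect of the two changes holds independently across the series.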